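The source may hold more compounds than are shown below. What is called first, only, known or untested is meant among the compounds shown, and "the series" means these compounds.

Compound 1 `O=C(NCCCCC(c1ccc(F)cc1)c1ccc(F)cc1)Nc1ccc(Cl)cc1` stands second highest of the three compounds measured in an ADME assay on isolated protein for inhibition of sodium-dependent dopamine transporter (Homo sapiens), tested at 10 uM (on this read-out higher numbers stand for more inhibition at the one concentration tested (going by the name of the read-out) and lower numbers for less inhibition), where compound 1 gives 82%. Within the data shown here, compound 2 `O=C(NCCCCC(c1ccc(F)cc1)c1ccc(F)cc1)Nc1ccc(Cl)c(C(F)(F)F)c1` gives 90%, and the single change a number 8 percentage points higher from compound 1 to compound 2 (within the scatter) shows that a trifluoromethyl in place of hydrogen on an aromatic carbon makes little difference. Compound 3 `O=C(CCCCC(c1ccc(F)cc1)c1ccc(F)cc1)Nc1ccc(Cl)c(C(F)(F)F)c1` carries the same aryl group as compound 2 but on an amide rather than a urea; in this assay compound 3 gives 33%. Compound 4 `O=C(NCCCCC(c1ccc(F)cc1)c1ccc(F)cc1)c1ccc(Cl)c(C(F)(F)F)c1` differs from compound 1 by 4-chloro-3-(trifluoromethyl)phenyl in place of (4-chlorophenyl)amino on a carbonyl carbon. Among the measured compounds shown here, only the step to compound 2 bears directly on this change, and it was small; the low value of compound 3 suggests that leaving the urea may cost activity. Compound 4 is therefore expected to show a number 32 percentage points lower from compound 1 to compound 4 (beyond the scatter), an estimated 50% within 25% to 78%.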

Compound 4, a percentage reported as inhibition, at one concentration (the size of the read-out at that concentration, not a potency): 51%
Compound 4: middle estimate off by 1 percentage points, on the low side, and the stated range covers the measured number.
By their numbers in this assay, from the lowest: compound 3; then compound 4; then compounds 1 and 2 (each within the scatter of the next).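

Placing 4-chloro-3-(trifluoromethyl)phenyl in place of (4-chlorophenyl)amino on the carbonyl carbon gives, in this assay, a number 31 percentage points lower from compound 1 to compound 4 (beyond the scatter), so the group on this carbonyl carbon clearly matters, whereas the earlier step, a number 8 percentage points higher from compound 1 to compound 2 (within the scatter), stayed within the scatter. This change removes the amino nitrogen with its hydrogen-bond donor and adds trifluoromethyl in one step, so the two cannot be separated here. No evidence available here accounts for the drop. The compounds shown leave open how a plain 4-chlorophenyl on this carbonyl carbon would read, and whether a methylene in place of the amino nitrogen would restore the higher number.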